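The source may hold more compounds than are shown below. What is called first, only, known or untested is meant among the compounds shown, and "the series" means these compounds.

Measured compounds:
- Compound 1 `COc1cc2ncnc(Nc3ccc(Cl)c(C(F)(F)F)c3)c2cc1OCCCCC(=O)Nc1ccc(S(N)(=O)=O)cc1`: in a functional assay on A549 cells (Homo sapiens) for antiproliferative activity, read by MTT assay, with a stated time of 72 h (a lower number here means a stronger inhibitor, a higher number a weaker inhibitor), compound 1 gives 9270 nM.
- Compound 2 `COc1cc2ncnc(Nc3cccc(Cl)c3)c2cc1OCCCCC(=O)Nc1ccc(S(N)(=O)=O)cc1`: in this assay compound 2 gives 11200 nM.
- Compound 3 `COc1ccc(Nc2ncnc3cc(OC)c(OCCCCC(=O)Nc4ccc(S(N)(=O)=O)cc4)cc23)cc1`: in this assay compound 3 gives only a limit, > 40000 nM.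

All three share one core and differ only in the aromatic group attached to the nitrogen on the core. Compound 3 stands weakest of the three on the numbers shown: its value is a limit of the assay, not a number, at the limit of > 40000 nM in this assay, at which 1 of the 3 values shown sits. The move to it was an at least 4.3-fold higher number from compound 1 to compound 3 (0.63 log units; beyond the scatter) and an at least 3.5-fold higher number from compound 2 to compound 3 (0.55 log units; beyond the scatter), both beyond the scatter, while a 1.2-fold higher number from compound 1 to compound 2 (0.08 log units; within the scatter) stayed within it.

Compound 4 `COc1cc2ncnc(Nc3ccc(C(F)(F)F)cc3)c2cc1OCCCCC(=O)Nc1ccc(S(N)(=O)=O)cc1` is not yet measured. It differs from compound 3 by trifluoromethyl in place of methoxy on an aromatic carbon. The two steps that bear on this are those into compound 3, which show that swapping the methoxy-bearing group for a halogen- or trifluoromethyl-bearing group is worth at least a modest step toward stronger inhibition. A trifluoromethyl group on its own is therefore expected to recover part of that, and the expected step is an at least 2.5-fold lower number from compound 3 to compound 4 (0.39 log units; beyond the scatter) in this assay. Compound 4 is estimated at 16000 nM, between 6000 nM and 45000 nM.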

Compound 4, half-maximal inhibitory concentration: 14800 nM
The estimate for compound 4 lay 1.1-fold (0.03 log units) above the measured number; measured number inside the range.
By their numbers in this assay, from the lowest: compounds 1, 2 and 4 (each within the scatter of the next). At a limit, above all of these: compound 3.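

In this assay, replacing methoxy with trifluoromethyl at this one position, para to a large group on the six-membered aromatic ring, gives an at least 2.7-fold lower number from compound 3 to compound 4 (0.43 log units; beyond the scatter), so this single change is enough to separate compound 3 from the rest, and compound 4 does it without any chlorine on that ring. The other two comparisons, a 1.3-fold higher number from compound 2 to compound 4 (0.12 log units; within the scatter) and a 1.6-fold higher number from compound 1 to compound 4 (0.20 log units; within the scatter), both lie within the scatter, which means that 4-(trifluoromethyl)phenyl, 3-chlorophenyl and 4-chloro-3-(trifluoromethyl)phenyl cannot be told apart here, and among these four compounds only the one with 4-methoxyphenyl stands apart. The value for compound 3 is a limit and not a number, so the first step gives only a minimum size and its true size stays unknown: the limit of > 40000 nM in this assay, at which 1 of the 4 values shown sits.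

What the compounds shown leave open is how other groups at this position would behave, such as an amine, a nitrile or a simple hydrogen, and whether methoxy would count against activity elsewhere on the ring. All four also share the same chain and the same sulfonamide end, so the effect of a longer chain, or of a carboxylic acid at that end, remains an open question.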